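A shared core, three limits, and one compound still unmeasured

This account rests on a few compounds, and the source may have more. Where it says the series, first, only, none or still open, it means among the compounds named here.

The study follows a shared core whose side chain on one aromatic ring is varied, and it asks whether any of these variants harms cells. Compound 1 `COc1ccc(C[C@H]2COC(=O)[C@@H]2Cc2ccc(OCC(=O)Nc3ccccc3)c(OC)c2)cc1OC` is the reference point. In an ADME assay on HeLa cells (Homo sapiens) for cytotoxicity, read by MTT assay (a lower number here means a stronger inhibitor, a higher number a weaker inhibitor), compound 1 reaches only a limit of the assay, >= 600000 nM, and not a number. Compound 2 `COC(=O)[C@@H](NC(=O)CCC(=O)Oc1ccc(C[C@H]2C(=O)OC[C@@H]2Cc2ccc(OC)c(OC)c2)cc1OC)c1c[nH]c2ccccc12` is reported in this assay at the same kind of limit, >= 600000 nM. Compound 3 `COc1ccc(C[C@H]2COC(=O)[C@@H]2Cc2ccc(OCc3cn(Cc4ccccc4F)nn3)c(OC)c2)cc1OC` likewise stops in this assay at a limit, >= 600000 nM. Compound 1 therefore stands nowhere in particular among the numbers shown: every value is a limit, and the only evidence available is the limit of >= 600000 nM in this assay, at which 3 of the 3 values shown sit, so no measured step between any two of these compounds can be stated.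

Compound 4 `COc1ccc(C[C@H]2COC(=O)[C@@H]2Cc2ccc(OCc3cn(-c4cccc(Cl)c4)nn3)c(OC)c2)cc1OC` has not yet been measured. It differs from compound 1 in one place: 1-(3-chlorophenyl)-1H-1,2,3-triazol-4-yl in place of phenylcarbamoyl on a saturated chain carbon bound to an oxygen on an aromatic ring. Among the measured compounds shown here, with no measured step to build on and all three values sitting at the ceiling, the step expected in this assay is a number no higher from compound 1 to compound 4 (the limit leaves the size open), that is, none beyond the scatter in either direction. Compound 4 is accordingly expected to give 600000 nM in this assay, within 300000 nM to 1200000 nM, and most probably to be reported again as a limit rather than a number.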

Compound 4, half-maximal inhibitory concentration: 493000 nM
Beside the measured number, compound 4's estimate is 1.2-fold (0.09 log units) above it; measured number inside the range.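

Among the compounds shown here, compound 4 is the first compound here to give a number rather than a limit in this assay, so a group on a saturated chain carbon bound to an oxygen on an aromatic ring can bring the read-out within the range of the assay. Putting 1-(3-chlorophenyl)-1H-1,2,3-triazol-4-yl in place of phenylcarbamoyl gives an at least 1.2-fold lower number from compound 1 to compound 4 (0.08 log units; that floor lies within the scatter), and putting 3-chlorophenyl in place of 2-fluorobenzyl on an aromatic nitrogen gives an at least 1.2-fold lower number from compound 3 to compound 4 (0.08 log units; that floor lies within the scatter). Both steps are floors rather than measured sizes, so neither change is shown to go beyond the scatter, and the picture of the set remains dominated by a single limit: the limit of >= 600000 nM in this assay, at which 3 of the 4 values shown sit.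

The compounds shown leave open whether the chlorine of compound 4 has any bearing on its number, or whether a 3-aminophenyl or 3-carboxyphenyl group on the same triazole would read the same. They also leave open what numbers compound 1 and compound 3 would give past their limits, and with that the true size of both steps.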